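The compounds below may be only part of what the source reports. "The series", "measured", "known", "first", "only" and "open" are said of these compounds alone.

Measured compounds:
Compound 1, `Cc1cccc2c1CC/C2=C\C(=O)NC1CC1`, in a functional assay on the whole organism with Rattus norvegicus as the target, at a dose of 20 mg/kg by the oral route; on this read-out higher numbers stand for more inhibition at the one dose given (going by the name of the read-out) and lower numbers for less inhibition: 15%
Compound 2, `NC(=O)/C=C1\CCc2ccc(Br)cc21`, in this assay: 38%
Compound 3, `Cc1cccc2c1CC/C2=C\C(N)=O`, in this assay: 15%

Compound 2 gives the highest of the three numbers; compound 1 and compound 3 both sit a number of percentage points lower, and those gaps are beyond the scatter. Compound 1 and compound 3 share a core, and compound 3 differs from compound 1 by cyclopropyl in place of hydrogen on an amide-type nitrogen. That change made the step of no change at the digits printed from compound 3 to compound 1 (within the scatter). The difference between the core of compound 2 and the core of compound 3 is not broken down here.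

Compound 4, `O=C(/C=C1\CCc2ccc(Br)cc21)NC1CC1`, is not yet measured. It differs from compound 2 by cyclopropyl in place of hydrogen on an amide-type nitrogen, the same change, at the same place, as from compound 3 to compound 1. Because that earlier step was no change at the digits printed from compound 3 to compound 1 (within the scatter), the expected step for compound 4 is about a number 3 percentage points lower from compound 2 to compound 4 (within the scatter), resting on one example only, so a wider spread is allowed. In this assay compound 4 is estimated at 35%, with 20% to 52% as the likely range.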

Compound 4, a percentage reported as inhibition, in the whole organism at one dose (the size of the read-out at that dose, not a potency): 29%
Compound 4: the middle estimate sits 6 percentage points above what was measured, within the range that was stated.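

In this assay, putting cyclopropyl in place of hydrogen on the amide-type nitrogen gives a number 9 percentage points lower from compound 2 to compound 4 (within the scatter). Set beside the same change on the other core, the two steps give no sign that the core alters what this change does: the same change on two cores in this assay, no change at the digits printed (within the scatter) from compound 3 to compound 1 and a number 9 percentage points lower (within the scatter) from compound 2 to compound 4, 9 percentage points apart, within the scatter of two such steps

This shows only that, on these two cores, the change leaves the read-out within the usual scatter, so the step seen on one core was a fair guide to the step on the other. It does not show that the two steps are truly identical, since a small difference could hide within that scatter, and two examples at a single dose cannot establish a rule for other cores.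

The compounds shown leave open whether a larger group on the same nitrogen, such as a longer chain or a benzyl group, would also leave the read-out within the scatter. They also leave open what a carboxylic acid in place of the amide would do on either core.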